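Halogen exchange on the anilide of compound 3

A few compounds are considered here, and "the series" means these few. Any claim that something is new, unique, unknown or untested is made for them only; others in the source may bear on it.

Compound 1 `CCOC(=O)C1=Cc2ccccc2OC1(OCc1cn(CC(=O)NC2CCCCC2)nn1)C(F)(F)F` in a functional assay on DU-145 cells (Homo sapiens) for inhibition, read by MTT assay, with a stated time of 24 h (on this read-out lower numbers stand for stronger inhibition and higher numbers for weaker inhibition), gives 10200 nM. Compound 2 `CCCCCCCCn1cc(COC2(C(F)(F)F)Oc3ccccc3C=C2C(=O)OCC)nn1` carries heptyl on the saturated chain carbon bound to the aromatic nitrogen. In this assay compound 2 reaches only the limit > 150000 nM. Compound 3 `CCOC(=O)C1=Cc2ccccc2OC1(OCc1cn(CC(=O)Nc2ccccc2Br)nn1)C(F)(F)F` carries (2-bromophenyl)carbamoyl at that carbon. In this assay compound 3 is likewise reported only as the limit > 150000 nM. Compound 3 therefore sits at the top edge of what the numbers show, together with compound 2 (the limit of > 150000 nM in this assay, at which 2 of the 3 values shown sit). The step of an at least 14-fold higher number from compound 1 to compound 3 (1.16 log units; beyond the scatter) is large, while the step that the two limits leave unreadable from compound 2 to compound 3 cannot be read. Compound 4 `CCOC(=O)C1=Cc2ccccc2OC1(OCc1cn(CC(=O)Nc2ccccc2F)nn1)C(F)(F)F` differs from compound 3 by fluoro in place of bromo on an aromatic carbon. For the measured compounds named here, no measured step alters a halogen on the six-membered aromatic ring; the one step touching this part, an at least 14-fold higher number from compound 1 to compound 3 (1.16 log units; beyond the scatter), introduced the whole 2-bromophenyl group. An exchange of one halogen for another there is expected to move the number little, so the step of an at least 1.5-fold lower number from compound 3 to compound 4 (0.17 log units; that floor lies within the scatter) is expected to be small and compound 4 is expected to remain near the limit. Compound 4 is estimated at 100000 nM, between 20000 nM and 300000 nM.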

Compound 4, half-maximal inhibitory concentration: 33900 nM
The estimate for compound 4 lay 2.9-fold (0.47 log units) above the measured number, and the stated range covers the measured number.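

In this assay the exchange of bromo for fluoro alone gives an at least 4.4-fold lower number from compound 3 to compound 4 (0.64 log units; beyond the scatter) and brings the anilide off the limit into a readable number, so this place on the aromatic ring responds to the identity of a single halogen. The 2-fluorophenyl amide also separates from the heptyl compound, with an at least 4.4-fold lower number from compound 2 to compound 4 (0.64 log units; beyond the scatter) where the 2-bromophenyl amide gave no readable step. A gap to the cyclohexyl amide remains, with a 3.3-fold higher number from compound 1 to compound 4 (0.52 log units; beyond the scatter) left over, and the two steps from the limits are only floors: the limit of > 150000 nM in this assay, at which 2 of the 4 values shown sit.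

Two halogens give no trend across the halogen series. Where chloro at this place would read stays open, as does whether a plain phenyl amide or an amine on the ring would follow fluoro or bromo.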